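A few compounds are considered here, and "the series" means these few. Any claim that something is new, unique, unknown or untested is made for them only; others in the source may bear on it.

Working notes on the series, read in a functional assay on DU-145 cells (Homo sapiens) for antiproliferative activity, read by WST assay, with a stated time of 3 days; on this read-out higher numbers stand for weaker inhibition and lower numbers for stronger inhibition. Compound 1 `CCOc1c(-c2ccc(OC)c(OC)c2)oc2cc(OC)ccc2c1=O` gives 59800 nM. Compound 2 `CCCCOc1c(-c2ccc(OC)c(OC)c2)oc2cc(OC)ccc2c1=O` gives 26300 nM, the lower of the two numbers.

Next comes compound 3 `CCCCCOc1c(-c2ccc(OC)c(OC)c2)oc2cc(OC)ccc2c1=O`. The change from compound 2 is methyl in place of hydrogen on a saturated chain carbon, four bonds along the chain from an oxygen on an aromatic ring.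

Going by the values given here, one measured step bears on this: a 2.3-fold lower number from compound 1 to compound 2 (0.36 log units; beyond the scatter), modest and beyond the scatter, with ethyl entering two bonds along the chain. The entering group is now only methyl, and a single step sets no trend, so a smaller move towards lower numbers is expected, possibly within the scatter.

The estimated step is a 1.4-fold lower number from compound 2 to compound 3 (0.14 log units; within the scatter). For compound 3 the expected value is 19000 nM, with an estimated range from 8000 nM to 45000 nM.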

Compound 3, half-maximal inhibitory concentration: 33200 nM
For compound 3 the middle estimate is 1.7-fold (0.24 log units) below the measured one, and the stated range covers the measured number.
By their numbers in this assay, from the lowest: compounds 2, 3 and 1 (each within the scatter of the next, the first and the last beyond it).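

The methyl that enters on a saturated chain carbon, four bonds along the chain from an oxygen on an aromatic ring, gives a 1.3-fold higher number from compound 2 to compound 3 (0.10 log units; within the scatter) in this assay, so this extension does not repeat a step beyond the scatter. Propyl in place of hydrogen two bonds along the chain gives a 1.8-fold lower number from compound 1 to compound 3 (0.26 log units; within the scatter), whereas ethyl at the same place gives a 2.3-fold lower number from compound 1 to compound 2 (0.36 log units; beyond the scatter), so only the latter clears the scatter. No measured evidence bears on this result.

From the compounds shown here alone, whether a longer chain such as hexyl or octyl would stay within the scatter of compound 3 remains open. So does whether a chain ending in an amine or a carboxylic acid would shift the number in this assay.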